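The compounds below may be only part of what the source reports. "The series", "measured", "known", "first", "only" and "open" are said of these compounds alone.

Measured compounds:
Compound 1, `COc1cc(/C=C/C(=O)/C=C/C2=C(C)CCCC2(C)C)ccc1O`, gives 9500 nM in a functional assay on LNCaP cells (Homo sapiens) for cytotoxicity, read by MTT assay, with a stated time of 72 h; a higher number here means a weaker inhibitor, a lower number a stronger inhibitor.
Compound 2, `COc1ccc(/C=C/C(=O)/C=C/C2=C(C)CCCC2(C)C)cc1O`, gives 9900 nM in this assay.

Of the two numbers recorded so far, compound 2 holds the higher one, but its nearest neighbour is compound 1, and the gap between them lies within the usual scatter of repeated measurements, so the two values show no difference worth naming. Going by the values given here, both compounds share the same core, and no single-point step links them.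

The next compound in the series is compound 3, `COc1ccc(/C=C/C(=O)/C=C/C2=C(C)CCCC2(C)C)cc1OC`. It differs from compound 2 in one place: methyl in place of hydrogen on an oxygen on an aromatic ring. Among the compounds with values here, no step between measured compounds of this kind is available, so nothing in the data at hand says how such a change shifts the read-out in this assay. In the absence of such a precedent, the expectation for compound 3 is a step from compound 2 of roughly a 1.2-fold higher number from compound 2 to compound 3 (0.08 log units; within the scatter), which is taken as no change beyond the scatter. On that basis compound 3 is estimated to give 12000 nM in this assay, with a plausible range from 5000 nM to 30000 nM.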

Compound 3, half-maximal inhibitory concentration: 9500 nM
Compound 3: the middle estimate sits 1.3-fold (0.10 log units) above what was measured; the measured number falls inside the stated range.
By their numbers in this assay, from the lowest: compounds 1, 3 and 2 (each within the scatter of the next).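

In this assay, methyl in place of hydrogen on an oxygen on an aromatic ring gives a 1.0-fold lower number from compound 2 to compound 3 (0.02 log units; within the scatter), and the same replacement read from the other hydroxy compound gives no change at the digits printed from compound 1 to compound 3 (within the scatter); both steps lie within the scatter. Going by these compounds alone, these are the first one-place steps, and they show that, for these compounds, hydroxy and methoxy on the ring cannot be told apart in this read-out, whichever of the two oxygens carries the hydroxy. No independent measurement bears on why the read-out stays within the scatter across this change.

The three compounds leave open whether anything at this oxygen can move the number beyond the scatter, since a longer chain such as a butyl ether, or an acetic acid group with its carboxylic acid, would test far more than the single methyl does. On these data alone, an amine in place of the hydroxy is equally open, as is any replacement away from the ring, on the rest of the shared core.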